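A few compounds are considered here, and "the series" means these few. Any claim that something is new, unique, unknown or untested is made for them only; others in the source may bear on it.

For the measured compounds named here, compound 2 `O=C(O)CCCCC1=CC[C@@H]2[C@@H](/C=C/[C@@H](O)COc3ccccc3)[C@H](O)C[C@@H]2OC1` gives the lowest of the two numbers so far: in a functional assay on CHO cells for agonist activity at prostaglandin F2-alpha receptor (Homo sapiens), read by fluorescence and calcium flux (a higher number here means that more compound is needed for the effect, a lower number that less compound is needed), compound 2 gives 73 nM, while compound 1 `O=C(O)CCC1=CC[C@@H]2[C@@H](/C=C/[C@@H](O)COc3ccccc3)[C@H](O)C[C@@H]2OC1` gives 530 nM. Compound 3 `O=C(O)CCCCCC1=CC[C@@H]2[C@@H](/C=C/[C@@H](O)COc3ccccc3)[C@H](O)C[C@@H]2OC1` carries the change (carboxymethyl in place of carboxy on a saturated chain carbon, four bonds along the chain from a double-bonded ring carbon). Going by the values given here, only one measured step bears on it: lengthening the same chain gave a 7.3-fold lower number from compound 1 to compound 2 (0.86 log units; beyond the scatter). One further carbon is expected to give a smaller gain, a 1.8-fold lower number from compound 2 to compound 3 (0.26 log units; within the scatter), since the earlier gain came from a longer extension. Compound 3 is therefore estimated at 40 nM, with a range from 10 nM to 200 nM.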

Compound 3, half-maximal effective concentration: 880 nM
For compound 3 the middle estimate is 22-fold (1.34 log units) below the measured one, outside the stated range (above it).
By their numbers in this assay, from the lowest: compound 2; then compounds 1 and 3 (each within the scatter of the next).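

In this assay, one further carbon on the chain reverses the earlier gain, with a 12-fold higher number from compound 2 to compound 3 (1.08 log units; beyond the scatter), so a longer chain does not keep lowering the number. The shortest and longest chains of the set end up close together, with a 1.7-fold higher number from compound 1 to compound 3 (0.22 log units; within the scatter), which leaves compound 2 alone at the lowest number. Nothing available explains this sharp turn at a single carbon.

Still open, on these data alone, is how a chain of a length between those of compound 1 and compound 2 would read. As far as these compounds go, it is also open whether a methyl ester or an amide at the chain end would preserve the number of compound 2.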